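Trimethoxyphenyl Pyrazole Enones: A Dichlorophenyl Replacement

A few compounds are considered here, and "the series" means these few. Any claim that something is new, unique, unknown or untested is made for them only; others in the source may bear on it.

Measured compounds:
- compound 1, `COc1ccc(-c2cc(/C=C/C(=O)c3ccc(N)cc3)[nH]n2)cc1`: 38200 nM
- compound 2, `COc1cc(-c2cc(/C=C/C(=O)c3ccc(N)cc3)[nH]n2)cc(OC)c1OC`: 6200 nM

Of the compounds shown here, two have been tested in a functional assay on MDA-MB-435 cells (Homo sapiens) for inhibition, read by sulforhodamine B assay, with a stated time of 48 h; on this read-out higher numbers stand for lower toxicity in this test and lower numbers for higher toxicity in this test. Compound 1 gives 38200 nM in this assay, and compound 2 gives 6200 nM. Compound 2 thus holds the lowest number of the two, and its gap to compound 1 lies beyond the scatter of this assay.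

Compound 3, `COc1cc(-c2cc(/C=C/C(=O)c3ccc(Cl)c(Cl)c3)[nH]n2)cc(OC)c1OC`, has not yet been measured. It differs from compound 2 by 3,4-dichlorophenyl in place of 4-aminophenyl on a carbonyl carbon. Among the compounds with values here, no step between measured compounds covers this change, so there is nothing within these data that speaks directly to its size or direction. The account therefore treats it as an open question and expects the step from compound 2 to compound 3 to be a modest one, within or just beyond the scatter, as a 1.3-fold higher number from compound 2 to compound 3 (0.11 log units; within the scatter).

For compound 3 the expected value in this assay is 8000 nM, in a range from 2500 nM to 25000 nM.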

Compound 3, concentration lethal to 50% of the cells: > 100000 nM
Compound 3: only a limit was reported (the forecaster's own chance of this, stated with the estimate: 5%); at least 12-fold (1.09 log units) between middle value and limit.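

Within the data shown here, compounds 1 and 2 both carry 4-aminophenyl on the carbonyl carbon, so they could say nothing about this place; compound 3 is the first to change it. In this assay compound 3 gives only a limit, > 100000 nM, not a number. Replacing 4-aminophenyl with 3,4-dichlorophenyl therefore gives an at least 16-fold higher number from compound 2 to compound 3 (1.20 log units; beyond the scatter), which shows that this place strongly affects the read-out in this pair, though the full size of the step stays unknown: the limit of > 100000 nM in this assay, at which 1 of the 3 values shown sits.

The compounds shown do not tell whether the step follows from losing the amine of 4-aminophenyl or from gaining the two chlorines. Going by these compounds, a plain phenyl or a 4-chlorophenyl on this carbonyl carbon would help separate the two, and it remains open whether the same change would act alike on the core of compound 1.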